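From compound 1 to compound 4: one ring exchanged

This account rests on a few compounds, and the source may have more. Where it says the series, first, only, none or still open, it means among the compounds named here.

Measured so far in an ADME assay on J774.A1 cells (Mus musculus) for cytotoxicity, read by MTT assay; on this read-out lower numbers stand for stronger inhibition and higher numbers for weaker inhibition
compound 1 `N#Cc1ccc(OCCCCCn2cc(/C=C3\NC(=O)NC3=O)c3ccccc32)cc1` gives 33 ug/mL
compound 2 `N#Cc1ccc(OCCCCCCn2cc(/C=C3\NC(=S)NC3=O)c3ccccc32)cc1` gives 2.3 ug/mL
compound 3 `N#Cc1ccc(OCCCCn2cc(/C=C3\NC(=S)NC3=O)c3ccccc32)cc1` gives > 100 ug/mL (a limit, not a number)

Compound 1 holds the higher of the two actual numbers, and the gap down to compound 2 lies beyond the usual scatter. Compound 3 has only a limit, so it cannot be placed exactly.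

The next compound, compound 4 `CN1C(=S)NC(=O)/C1=C\c1cn(CCCCCOc2ccc(C#N)cc2)c2ccccc12`, departs from compound 1 at one place: a group of 9 heavy atoms (5 carbon, 2 nitrogen, 1 oxygen, 1 sulfur; one five-membered non-aromatic ring with 2 hetero atoms) in place of a group of 8 heavy atoms (4 carbon, 2 nitrogen, 2 oxygen; one five-membered non-aromatic ring with 2 hetero atoms), on an aromatic carbon. Within the data shown here, no pair of measured compounds differs in just one place, so no direct step is available to guide the expectation. The new group contains sulfur in its five-membered ring, and that ring in compound 2 also contains sulfur, with a value of 2.3 ug/mL. Compound 3 has sulfur there too, yet its > 100 ug/mL is a limit. These two results give only weak guidance, so only a modest shift is expected, and it may not clear the scatter. In this assay the expected change, toward a lower number, is a 2.2-fold lower number from compound 1 to compound 4 (0.34 log units; beyond the scatter). For compound 4 the estimated value is 15 ug/mL, with an expected range from 3 ug/mL to 70 ug/mL.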

Compound 4, half-maximal inhibitory concentration: 14.8 ug/mL
Compound 4: middle estimate off by 1.0-fold (0.01 log units), on the high side; low and high end bracket the measured number.
By their numbers in this assay, from the lowest: compound 2; then compound 4; then compound 1. At a limit, above all of these: compound 3.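

Among these compounds, the exchange gives the first step here between compounds that differ in one place, on an aromatic carbon of the five-membered aromatic ring: in this assay, there is a 2.2-fold lower number from compound 1 to compound 4 (0.35 log units; beyond the scatter). So this position is not silent: swapping one five-membered non-aromatic ring for another, with sulfur entering and 1 hydrogen-bond donor where the leaving group has 2, moves the read-out modestly but past the usual scatter, toward stronger inhibition of the cells, which on this read-out signals greater cytotoxicity. Both ends of this step are actual numbers, so its size can be read directly, whereas compound 3 gives only a limit and offers no such reading: the limit of > 100 ug/mL in this assay, at which 1 of the 4 values shown sits.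

The exchange brings in sulfur, loses oxygen and adds a carbon all at once, and the compounds shown do not separate these changes or tell which of them accounts for the step. As far as these compounds go, how the same position would read in this assay with a ring bearing an ethyl group, an amine or a carboxylic acid also remains open.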